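This account rests on a few compounds, and the source may have more. Where it says the series, first, only, none or still open, it means among the compounds named here.

Measured in an ADME assay on PBMC cells (Homo sapiens) for cytotoxicity, with a stated time of 5 days (a higher number here means a weaker inhibitor, a lower number a stronger inhibitor), each entry a limit and not a number:
compound 1 `CC(C)(CO)Nc1nc(N)nc2c1ncn2[C@H]1C[C@H](N=[N+]=[N-])[C@@H](CO)O1`: > 100000 nM
compound 2 `C=CCNc1nc(N)nc2c1ncn2[C@H]1C[C@H](N=[N+]=[N-])[C@@H](CO)O1`: > 100000 nM
compound 3 `CN(C)c1nc(N)nc2c1ncn2[C@H]1C[C@H](N=[N+]=[N-])[C@@H](CO)O1`: > 100000 nM

Compound 3 is known only through a limit, and its two companions are no different: this is the limit of > 100000 nM in this assay, at which 3 of the 3 values shown sit, so no ranking can be drawn among the three.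

Going on to compound 4 `CN(C)c1nc(Cl)nc2c1ncn2[C@H]1C[C@H](N=[N+]=[N-])[C@@H](CO)O1`, chloro takes the place of amino on an aromatic carbon between two ring nitrogen atoms, chloro in place of amino on an aromatic carbon while the dimethylamino group stays. The measured steps give little to work with. They are a step that the two limits leave unreadable from compound 1 to compound 2, a step that the two limits leave unreadable from compound 1 to compound 3 and a step that the two limits leave unreadable from compound 2 to compound 3, and none has a size that can be carried over. None of them changes the amino group that leaves here, so the effect of this replacement has not been measured in the series.

The expectation therefore rests only on the position of compound 3, whose limit is > 100000 nM in this assay as it stands. The expected step, a number no higher from compound 3 to compound 4 (the limit leaves the size open), is none beyond the scatter, in neither direction. For compound 4 the estimate is 100000 nM, expected within 30000 nM to 100000 nM as a range, and a further limit is the likeliest report.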

Compound 4, half-maximal inhibitory concentration: > 100000 nM
Compound 4 was reported as a limit; the forecaster's own chance of this, stated with the estimate: 70%; the middle value lies on the limit itself.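

In this assay no step can be read from compound 3 to compound 4, with chloro in place of amino, because both entries are limits and not numbers: the limit of > 100000 nM in this assay, at which 4 of the 4 values shown sit.

The compounds shown leave open whether any of these changes on the shared core shifts the half-maximal inhibitory concentration at all.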